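Swapping the Aryl Group on a Furoate Ester Series

The source may hold more compounds than are shown below. What is called first, only, known or untested is meant among the compounds shown, and "the series" means these compounds.

Two compounds share one core and differ only in the ring hung on its five-membered aromatic ring. Compound 1 `COc1cc(COC(=O)c2ccc(-c3ccc(Cl)cc3Cl)o2)cc(OC)c1OC` gives 38.3% in an assay on isolated protein for inhibition of high affinity 3',5'-cyclic-AMP phosphodiesterase 7A (Homo sapiens), read by scintillation proximity assay and cAMP accumulation, with a stated time of 20 min, tested at 10 uM; on this read-out lower numbers stand for less inhibition and higher numbers for more inhibition at the one concentration tested (going by the name of the read-out). Compound 2 `COc1cc(COC(=O)c2ccc(-c3cccc(C(F)(F)F)c3)o2)cc(OC)c1OC` gives 14% in this assay, the lowest of the two numbers, and the step of a number 24.3 percentage points lower from compound 1 to compound 2 (beyond the scatter) lies beyond the scatter. Compound 3 `COc1cc(COC(=O)c2ccc(-c3ccc(C)cc3)o2)cc(OC)c1OC` is not yet measured; it differs from compound 2 by 4-methylphenyl in place of 3-(trifluoromethyl)phenyl on an aromatic carbon. Among the compounds with values here, the only measured step, a number 24.3 percentage points lower from compound 1 to compound 2 (beyond the scatter), changes the same position and shows that this group can move the read-out by a modest amount, but neither measured compound carries 4-methylphenyl, so the direction for compound 3 is uncertain. Compound 3 is therefore expected to land between the two measured numbers, a step of a number 11 percentage points higher from compound 2 to compound 3 (beyond the scatter) upward. The estimate for compound 3 is 25%, with a likely range from 5% to 45%.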

Compound 3, a percentage reported as inhibition, at one concentration (the size of the read-out at that concentration, not a potency): 30.7%
Compound 3: middle estimate off by 5.7 percentage points, on the low side; the measured number falls inside the stated range.
By their numbers in this assay, from the lowest: compound 2; then compounds 3 and 1 (each within the scatter of the next).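

In this assay, 4-methylphenyl in place of 3-(trifluoromethyl)phenyl gives a number 16.7 percentage points higher from compound 2 to compound 3 (beyond the scatter), so the low number of compound 2 does not hold for every aryl group at this position. Against 2,4-dichlorophenyl, the same 4-methylphenyl gives a number 7.6 percentage points lower from compound 1 to compound 3 (within the scatter), so this read-out does not separate compound 1 from compound 3 despite their different ring substituents, and of the three compounds only compound 2 stands apart from the other two. Nothing available explains why the 3-(trifluoromethyl)phenyl compound stands apart.

These compounds leave open whether the identity of a ring substituent or its place on the phenyl ring matters more, since no single substituent appears at two places. They also leave open how this position would respond to a phenyl ring carrying an amine or a carboxylic acid.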